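Methyl for Ethoxy on the Aryl Ring of Compound 3

This account rests on a few compounds, and the source may have more. Where it says the series, first, only, none or still open, it means among the compounds named here.

Measured compounds:
compound 1, `COc1ccccc1N1CCN(CCCNc2ccncc2C(=O)N(C)C)CC1`, 12.6 nM;
compound 2, `COc1ccccc1N1CCN(CCCOc2ccccc2C(=O)N(C)C)CC1`, 3.98 nM;
compound 3, `CCOc1ccccc1N1CCN(CCCNc2ncccc2C(=O)N(C)C)CC1`, 0.501 nM.

All three were tested in a functional assay for antagonist activity at Alpha-1A adrenergic receptor (Oryctolagus cuniculus); on this read-out higher numbers stand for weaker binding and lower numbers for tighter binding. Compound 3 stands at the lowest number of the three, and its distance from compound 2 as well as from compound 1 lies beyond the scatter, so on these numbers compound 3 is the tightest binder of the set. The value of compound 3 is 0.501 nM.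

Compound 4, `Cc1ccccc1N1CCN(CCCNc2ncccc2C(=O)N(C)C)CC1`, has not yet been measured. It differs from compound 3 in one place: methyl in place of ethoxy on an aromatic carbon. Going by the values given here, nothing among the measured compounds shows this change on its own, since compounds 1 and 2 differ from compound 3 in more than one respect; the expectation for compound 4 therefore rests on the number for compound 3 alone. The account expects the step from compound 3 to compound 4 to be a 4.0-fold higher number from compound 3 to compound 4 (0.60 log units; beyond the scatter), that is a moderate move toward weaker binding, beyond the scatter. For compound 4 the estimate is 2 nM, with a range from 0.5 nM to 8 nM.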

Compound 4, dissociation constant: 2 nM
Compound 4: the middle estimate sits on the measured number at the digits printed, and the stated range covers the measured number.
By their numbers in this assay, from the lowest: compound 3; then compounds 4 and 2 (each within the scatter of the next); then compound 1.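

In this assay, going by these compounds alone, the change from 2-ethoxyphenyl to 2-methylphenyl is the first in this set that can be read on its own, and it gives a 4.0-fold higher number from compound 3 to compound 4 (0.60 log units; beyond the scatter). At this place, on an aromatic carbon ortho to a large group, ethoxy therefore gives tighter binding than methyl, though the step is modest and methyl costs only part of the binding. No evidence is at hand that bears on what lies behind this step.

The compounds shown leave open how a methoxy group on the core of compound 3 would read, and with it whether the oxygen or the longer chain of ethoxy accounts for the step. From the compounds shown here alone, it is equally open how an isopropoxy group or a chlorine would read at this place, and whether the step keeps its size on the cores of compound 1 and compound 2.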